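Working notes: from compound 2 to compound 3

The source may hold more compounds than are shown below. What is called first, only, known or untested is meant among the compounds shown, and "the series" means these compounds.

Measured in a physicochemical assay for solubility, at pH 7.4; a lower number here means a less soluble compound, a higher number a more soluble compound:
- compound 1 `O=C(N[C@H]1CN(S(=O)(=O)c2ccccc2)C[C@@H]1C(=O)N[C@H]1CCCNC1)c1cc(-c2ccccc2)on1`: 94000 nM
- compound 2 `O=C(N[C@H]1CN(S(=O)(=O)c2ccccc2)C[C@@H]1C(=O)N[C@H]1CCCNC1)c1nnc(-c2ccc(F)cc2)s1`: 234000 nM

Of the two measured compounds, compound 2 stands highest at 234000 nM. Compound 3 `O=C(N[C@H]1CN(S(=O)(=O)c2ccccc2)C[C@@H]1C(=O)N[C@H]1CCCNC1)c1cc(-c2ccc(Cl)cc2)on1` departs from it as follows: a group of 12 heavy atoms (9 carbon, 1 nitrogen, 1 oxygen, 1 chlorine; one five-membered aromatic ring with 2 hetero atoms, one six-membered aromatic ring of carbon only) in place of a group of 12 heavy atoms (8 carbon, 2 nitrogen, 1 fluorine, 1 sulfur; one five-membered aromatic ring with 3 hetero atoms, one six-membered aromatic ring of carbon only), on a carbonyl carbon. Within the data shown here, the change falls on a carbonyl carbon, the same place as the one measured step, a 2.5-fold higher number from compound 1 to compound 2 (0.40 log units; beyond the scatter), which is modest and beyond the scatter. Compound 3 carries the five-membered aromatic ring with 2 hetero atoms found in compound 1, so that step bears on this one in reverse. No measurement isolates the chlorine. A fall of about the same size is therefore expected in this assay, though one step is thin support. The expected change is a 2.9-fold lower number from compound 2 to compound 3 (0.47 log units; beyond the scatter). Compound 3 is estimated at 80000 nM, with an expected range of 30000 nM to 190000 nM.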

Compound 3, solubility: 12000 nM
Compound 3: the middle estimate sits 6.7-fold (0.82 log units) above what was measured; the whole stated range lies above it.
By their numbers in this assay, from the lowest: compound 3; then compound 1; then compound 2.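

Chloro in place of hydrogen on an aromatic carbon gives a 7.8-fold lower number from compound 1 to compound 3 (0.89 log units; beyond the scatter) in this assay and is the first single-atom change read in the series. The exchange of the whole group on the carbonyl carbon gives a 20-fold lower number from compound 2 to compound 3 (1.29 log units; beyond the scatter) and shows that this position spans a far wider range than a 2.5-fold higher number from compound 1 to compound 2 (0.40 log units; beyond the scatter) alone suggested. Compound 3 now has the lowest number of the three, with its steps to both others beyond the scatter.

From the compounds shown here alone, the step to compound 3 from compound 2 changes the five-membered ring and the halogen together, so the share of each stays open, as does the outcome for a methoxy group or a dimethylamino group in place of the chloro. Measured evidence on the origin of these steps is lacking.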